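A few compounds are considered here, and "the series" means these few. Any claim that something is new, unique, unknown or untested is made for them only; others in the source may bear on it.

For the measured compounds named here, compound 1 `O=C(O)c1cccc(S(=O)(=O)N2CCC(NS(=O)(=O)c3cc(S(=O)(=O)c4ccccc4)ccc3C(F)(F)F)CC2)c1` is one of three compounds measured in a physicochemical assay for solubility (a higher number here means a more soluble compound, a lower number a less soluble compound), and compound 1 gives 12500 nM. That is the lowest of the three numbers. Compound 3 `CC(C)(C)OC(=O)N1CCC(C(=O)N2CCC(NS(=O)(=O)c3cc(S(=O)(=O)c4ccccc4)ccc3C(F)(F)F)CC2)CC1` gives 25000 nM, and the gap between compound 1 and compound 3 lies within the usual scatter. Compound 2 `O=S(=O)(NC1CCN(S(=O)(=O)c2cccc(-c3nnn[nH]3)c2)CC1)c1cc(S(=O)(=O)c2ccccc2)ccc1C(F)(F)F` gives 100000 nM, and the change an 8.0-fold higher number from compound 1 to compound 2 (0.90 log units; beyond the scatter) is beyond the scatter.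

Compound 4 `O=C([C@H]1CCNC1)N1CCC(NS(=O)(=O)c2cc(S(=O)(=O)c3ccccc3)ccc2C(F)(F)F)CC1` is not yet measured. It differs from compound 1 in one place: (pyrrolidin-3-yl)carbonyl in place of (3-carboxyphenyl)sulfonyl on an amine nitrogen in a ring. Going by the values given here, the only measured step that touches the same place is the one from compound 1 to compound 2, where swapping the group on the aromatic ring raised the number by a modest amount. The step to compound 4 is a larger rewrite of the whole group, and compound 3, which carries a different group at the same place, shows a number that sits within the scatter of compound 1. Taken together the data give a weak lean toward a higher number for compound 4 rather than a lower one, with wide uncertainty. The estimate for compound 4 in this assay is 80000 nM, expected to lie between 15000 nM and 400000 nM, which would mean an expected step of a 6.4-fold higher number from compound 1 to compound 4 (0.81 log units; beyond the scatter).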

Compound 4, solubility: 25000 nM
Estimate against measurement, compound 4: 3.2-fold (0.51 log units) above, and the stated range covers the measured number.
By their numbers in this assay, from the lowest: compounds 1, 3 and 4 (each within the scatter of the next); then compound 2.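

In this assay, the whole (3-carboxyphenyl)sulfonyl group on the amine nitrogen in the ring gives way to (pyrrolidin-3-yl)carbonyl, and the result is a 2.0-fold higher number from compound 1 to compound 4 (0.30 log units; within the scatter). For the compounds shown here, the only earlier step at this group altered a single substituent on its aromatic ring, an 8.0-fold higher number from compound 1 to compound 2 (0.90 log units; beyond the scatter), whereas this one shows that a far larger rewrite, which removes the aromatic ring and the sulfonyl and replaces 12 heavy atoms with 7, can leave the number within the usual scatter. No measured evidence here explains why the number stays within that scatter.

The compounds shown leave open whether the nitrogen of the pyrrolidine ring matters at this position, a question that a cyclopentylcarbonyl group, with carbon in place of that nitrogen, would address, and whether the defined stereocentre matters, which the opposite stereoisomer would address. They also leave open how much of the new group is needed at all, since a simple acetyl group on the same nitrogen would keep the carbonyl and drop the ring entirely.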